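From pyridin-3-yl to furan-2-yl on a shared core

The compounds below may be only part of what the source reports. "The series", "measured", "known", "first", "only" and "open" are said of these compounds alone.

In a functional assay on A-375 cells (Homo sapiens) for antiproliferative activity (a higher number here means a weaker inhibitor, a lower number a stronger inhibitor), compound 1 `O=C(Nc1ccc(-c2cscn2)cc1)C1CCCN(Cc2cccc(F)c2)C1` gives 2450 nM. Compound 2 `O=C(Nc1ccc(-c2cscn2)cc1)C1CCCN(Cc2cccc(OC(F)(F)F)c2)C1` reaches only a limit of the assay, > 20000 nM. Among the numbers that are actual values, compound 3 `O=C(Nc1ccc(-c2cccnc2)cc1)C1CCCN(Cc2ccc(F)c(F)c2)C1` is the lower of the two at 610 nM, and the gap to compound 1 at 2450 nM lies beyond the scatter. Compounds 1 and 3 differ in more than one place, so that gap cannot be assigned to any single change.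

Compound 4 `O=C(Nc1ccc(-c2ccco2)cc1)C1CCCN(Cc2ccc(F)c(F)c2)C1` differs from compound 3 by furan-2-yl in place of pyridin-3-yl on an aromatic carbon, para to a large group. For the measured compounds named here, the only measured single change, trifluoromethoxy in place of fluoro, gave an at least 8.1-fold higher number from compound 1 to compound 2 (0.91 log units; beyond the scatter). It shows that one exchange in this series can move this assay a long way, but it concerns another group at another place and gives no direct size for this swap. Going by the values given here, no measured step covers this exchange, so only a small rise is anticipated, with a wide margin. The expected step is a 1.3-fold higher number from compound 3 to compound 4 (0.12 log units; within the scatter), which is not clearly beyond the scatter. Compound 4 is estimated at 800 nM, with an expected range from 250 nM to 2500 nM.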

Compound 4, half-maximal inhibitory concentration: 1040 nM
Compound 4: middle estimate off by 1.3-fold (0.11 log units), on the low side; measured number inside the range.
By their numbers in this assay, from the lowest: compounds 3 and 4 (each within the scatter of the next); then compound 1. At a limit, above all of these: compound 2.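

In this assay, furan-2-yl in place of pyridin-3-yl, a five-membered aromatic ring for a six-membered one, each with one hetero atom, on an aromatic carbon para to a large group gives a 1.7-fold higher number from compound 3 to compound 4 (0.23 log units; within the scatter), so compound 3 and compound 4 cannot be told apart and this place accepts either ring in this assay. For the compounds shown here, this is the first single change to stay within the scatter, whereas the exchange of fluoro for trifluoromethoxy at another place, which ends at a limit of the assay, gave an at least 8.1-fold higher number from compound 1 to compound 2 (0.91 log units; beyond the scatter). The data shown hold nothing that accounts for the step between the two rings.

On these data alone, it remains open whether a phenyl ring, or a ring bearing an amine or a carboxylic acid, would also sit at this place without a step beyond the scatter. As far as these compounds go, compounds 1 and 3 differ in more than one place, and what the ring at this place contributes to the gap between them also stays open.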